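A few compounds are considered here, and "the series" means these few. Any claim that something is new, unique, unknown or untested is made for them only; others in the source may bear on it.

Compounds measured in an assay on HeLa cells for displacement of a labelled ligand from 5-hydroxytryptamine receptor 6 (Homo sapiens); on this read-out higher numbers stand for weaker inhibition and lower numbers for stronger inhibition:

compound 1, `CCN1CCN(c2cn(S(=O)(=O)c3ccc(C(C)C)cc3)c3ccc(Cl)cc23)CC1`, 30.5 nM
compound 2, `CCN1CCN(c2cn(S(=O)(=O)c3ccc(F)cc3)c3ccc(Br)cc23)CC1`, 10.6 nM
compound 3, `CCN1CCN(c2cn(S(=O)(=O)c3ccccc3Br)c3ccc(Cl)cc23)CC1`, 20.3 nM

Compound 3 stands second highest of the three numbers, with compound 1 nearest to it and compound 2 furthest, both gaps within the scatter. Compound 4, `CCN1CCN(c2cn(S(=O)(=O)c3ccc(F)cc3)c3ccc(Cl)cc23)CC1`, is not yet measured. It differs from compound 3 in one place: 4-fluorophenyl in place of 2-bromophenyl on a sulfonyl sulfur.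

Within the data shown here, only one measured step touches this sulfonyl position, the step of a 1.5-fold lower number from compound 1 to compound 3 (0.18 log units; within the scatter), and it stayed within the scatter. Compound 2 already carries the 4-fluorophenyl group on its sulfonyl sulfur, though its core differs from that of compound 4 in one other place, so its value can only be read as an indication. Taken together, a step of no real size beyond the scatter is expected in this assay, with the number for compound 4 expected to lie close to those of compound 3 and compound 2; the expected step is a 1.6-fold lower number from compound 3 to compound 4 (0.19 log units; within the scatter). Compound 4 is therefore estimated at 13 nM, with a range from 5 nM to 32 nM.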

Compound 4, inhibition constant: 10.7 nM
The estimate for compound 4 lay 1.2-fold (0.08 log units) above the measured number; the range from low to high includes it.
By their numbers in this assay, from the lowest: compounds 2, 4, 3 and 1 (each within the scatter of the next, the first and the last beyond it).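

In this assay, among these compounds, the exchange of 2-bromophenyl for 4-fluorophenyl on the sulfonyl sulfur does not separate the two compounds (a 1.9-fold lower number from compound 3 to compound 4 (0.28 log units; within the scatter)), whereas fluoro in place of isopropyl on an aromatic carbon gives the first step at this aryl group to pass beyond the scatter, though only modestly (a 2.9-fold lower number from compound 1 to compound 4 (0.45 log units; beyond the scatter)). With the 4-fluorophenyl group held constant, chloro in place of bromo on an aromatic carbon leaves the number unchanged (a 1.0-fold higher number from compound 2 to compound 4 (0.00 log units; within the scatter)). No evidence at hand bears on these results.

The step between compound 3 and compound 4 changes both the halogen and its place on the ring, so the two contributions cannot be told apart without a group such as 4-bromophenyl. On these data alone, whether an amine or a carboxylic acid on this ring would be accepted also remains open.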